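This account rests on a few compounds, and the source may have more. Where it says the series, first, only, none or still open, it means among the compounds named here.

Measured compounds:
Compound 1, `CC(C)N1CCC(c2ccc3c(c2)oc(=O)n3C(=O)NCCCCc2ccccc2)CC1`: 94 nM
Compound 2, `CC(C)CNC(=O)n1c(=O)oc2cc(C3CCCCN3C)ccc21`: 1010 nM

Both compounds share one core and were tested in an assay on HEK293 cells for inhibition of acid ceramidase (Homo sapiens), read by fluorescence, with stated times of 10 min and 3 h; a lower number here means a stronger inhibitor, a higher number a weaker inhibitor. Compound 1 gives 94 nM, while compound 2 gives 1010 nM. Compound 1 therefore stands lowest of the two numbers, and its gap to compound 2 lies beyond the usual scatter. Compound 2 differs from compound 1 in more than one place, so these two values alone do not tie the gap to any single change.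

Compound 3, `CN1CCC(c2ccc3c(c2)oc(=O)n3C(=O)NCCCCc2ccccc2)CC1`, has not yet been measured in this assay. It differs from compound 1 by methyl in place of isopropyl on an amine nitrogen in a ring. Within the data shown here, no measured pair shows this change on its own, so nothing in the data says how far it moves the number. The expected step is a 1.4-fold higher number from compound 1 to compound 3 (0.14 log units; within the scatter), small and within the usual scatter, since the rest of compound 1 is kept unchanged. The estimate for compound 3 is 130 nM, with a range from 45 nM to 400 nM.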

Compound 3, half-maximal inhibitory concentration: 129 nM
Compound 3: the middle estimate sits 1.0-fold (0.00 log units) above what was measured; measured number inside the range.
By their numbers in this assay, from the lowest: compounds 1 and 3 (each within the scatter of the next); then compound 2.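

In this assay, among these compounds, methyl in place of isopropyl on the amine nitrogen in the ring gives a 1.4-fold higher number from compound 1 to compound 3 (0.14 log units; within the scatter) and offers the first reading of a change in a single place. At this position, going from isopropyl to methyl, with 3 heavy atoms leaving and 1 entering, leaves the number within the scatter, so this pair shows no measurable preference between the two groups. Nothing measured here accounts for that result.

As far as these compounds go, whether the same holds for a hydrogen on that nitrogen, or for a larger group such as benzyl, remains open. Also open, from the compounds shown here alone, is which of the several differences between compound 1 and compound 2 carries their gap, and whether the longer chain on the shared core plays any part in it.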